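Ethynyl in place of furan-2-yl: working notes

The source may report more compounds than this note shows. Statements on the series, on what has been measured and on what is new or still open speak of the compounds shown alone.

Values in a functional assay on HepG2 cells (Homo sapiens) for antiproliferative activity, read by XTT assay, with a stated time of 72 h; on this read-out lower numbers stand for stronger inhibition and higher numbers for weaker inhibition:
Compound 1 `CSc1ncnc2c1c(-c1ccsc1)cn2[C@@H]1O[C@H](CO)[C@@H](O)[C@H]1O`: > 15000 nM, a limit.
Compound 2 `CSc1ncnc2c1c(-c1ccccc1)cn2[C@@H]1O[C@H](CO)[C@@H](O)[C@H]1O`: > 20000 nM, a limit.
Compound 3 `CNc1ncnc2c1c(-c1ccco1)cn2[C@@H]1O[C@H](CO)[C@@H](O)[C@H]1O`: 850 nM.

For the measured compounds named here, compound 3 holds the only number in the set, since the other two entries are limits. Compound 4 `C#Cc1cn([C@@H]2O[C@H](CO)[C@@H](O)[C@H]2O)c2ncnc(NC)c12` differs from compound 3 in one place: ethynyl in place of furan-2-yl on an aromatic carbon. Going by the values given here, the only measured step is a step that the two limits leave unreadable from compound 1 to compound 2. It involves neither furan-2-yl nor ethynyl, so it offers no size to carry over, and no direction is expected in this assay. The expectation therefore stays close to compound 3 at 850 nM, with a wide margin. The expected step is a 1.2-fold higher number from compound 3 to compound 4 (0.07 log units; within the scatter). For compound 4 the estimated value is 1000 nM, with an expected range from 120 nM to 10000 nM.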

Compound 4, half-maximal inhibitory concentration: > 15000 nM
Compound 4 ended at the assay's limit; the forecaster's own chance of this, stated with the estimate: 15%; middle value at least 15-fold (1.17 log units) away from the limit.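

In this assay, for the compounds shown here, ethynyl in place of furan-2-yl on this aromatic carbon gives an at least 17-fold higher number from compound 3 to compound 4 (1.24 log units; beyond the scatter), the only readable step in the set, as the step from compound 1 to compound 2 cannot be read. The group at this position can therefore move the read-out well beyond the scatter while the rest of compound 3 stays unchanged. Compound 4 sits at a limit, so this step gives only a lower bound on the size of the change: the limit of > 15000 nM in this assay, at which 2 of the 4 values shown sit.

Only furan-2-yl gives a number at this position. As far as these compounds go, whether a longer chain such as prop-1-ynyl or an aminomethyl group here would restore a number remains open.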